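Working notes: the aryl group on the carbonyl carbon

The source may report more compounds than this note shows. Statements on the series, on what has been measured and on what is new or still open speak of the compounds shown alone.

Values in a functional assay on MDA-MB-231 cells (Homo sapiens) for antiproliferative activity, with a stated time of 4 days; a lower number here means a stronger inhibitor, a higher number a weaker inhibitor:
- compound 1 `CCCCc1ccc2[nH]c(-c3ccc(OC)cc3)c(/C=N/NC(=O)c3ccc(OC)cc3)c2c1`: 61 nM
- compound 2 `CCCCc1ccc2[nH]c(-c3ccc(OC)cc3)c(/C=N/NC(=O)c3ccccc3OC)c2c1`: 21 nM

Compound 2, at 21 nM, holds the lower of the two numbers. The next compound is compound 3 `CCCCc1ccc2[nH]c(-c3ccc(OC)cc3)c(/C=N/NC(=O)c3cccc(O)c3)c2c1`, which carries 3-hydroxyphenyl in place of 2-methoxyphenyl on a carbonyl carbon. Going by the values given here, only one measured step bears on this change: a 2.9-fold lower number from compound 1 to compound 2 (0.46 log units; beyond the scatter). It is modest but beyond the scatter, and it occurs at the same place. Among the compounds with values here, no compound with a 3-hydroxyphenyl group has been measured, so the evidence is thin. Compound 1, which lacks the 2-methoxyphenyl group, stands at 61 nM, and a similar loss is expected on leaving that group. A step of similar size toward a higher number is therefore expected in this assay, estimated as a 2.9-fold higher number from compound 2 to compound 3 (0.46 log units; beyond the scatter). The estimated value for compound 3 is 60 nM, with an expected range of 20 nM to 180 nM.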

Compound 3, half-maximal inhibitory concentration: 30 nM
The estimate for compound 3 lay 2.0-fold (0.30 log units) above the measured number, and the stated range covers the measured number.
By their numbers in this assay, from the lowest: compounds 2 and 3 (each within the scatter of the next); then compound 1.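

In this assay, 3-hydroxyphenyl in place of 2-methoxyphenyl on a carbonyl carbon gives a 1.4-fold higher number from compound 2 to compound 3 (0.15 log units; within the scatter), so these two aryl groups cannot be told apart here. The same group in place of 4-methoxyphenyl gives a 2.0-fold lower number from compound 1 to compound 3 (0.31 log units; beyond the scatter), which shows that a methoxy group is not needed at this place for a number within the scatter of compound 2, and compound 1 stands apart from both other compounds. No measured data on the compounds bear on what lies behind these steps.

Compounds 2 and 3 differ in both the substituent and its place on the phenyl group, so the contribution of each remains unresolved. Also open, going by these compounds, is how this position responds to an unsubstituted phenyl group, or to an amine or a carboxylic acid on the phenyl group.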